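From phenyl to 2,4-difluorophenyl on compound 3

The source may hold more compounds than are shown below. What is called first, only, known or untested is meant among the compounds shown, and "the series" means these compounds.

Going by the values given here, in a functional assay on RAW264.7 cells (Mus musculus), with a stated time of 3 days (on this read-out higher numbers stand for weaker inhibition and lower numbers for stronger inhibition), three compounds with a shared core have numbers so far. Compound 1 (`COc1cnc(-c2ccccn2)nc1N(C)C1CCCC1`) gives 180 nM as its result, compound 2 (`COc1cnc(-c2ccccn2)nc1NCc1ccccc1C(F)(F)F`) gives 230 nM as its result, and compound 3 (`COc1cnc(-c2ccccn2)nc1NCc1ccccc1`) gives 420 nM as its result. Compound 3 therefore stands within the usual scatter of compound 2, while compound 1 shows a lower number, and that gap lies beyond the scatter.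

The next compound, compound 4 (`COc1cnc(-c2ccccn2)nc1NCc1ccc(F)cc1F`), differs from compound 3 in one place: 2,4-difluorophenyl in place of phenyl on a saturated chain carbon bound to a nitrogen on an aromatic ring. Among the compounds with values here, only one measured step bears on this change, since it also alters a group on that phenyl. Hydrogen in place of trifluoromethyl on an aromatic carbon gives a 1.8-fold higher number from compound 2 to compound 3 (0.26 log units; within the scatter) in this assay and so offers no sign of a large effect. Within the data shown here, no measured compound carries fluorine directly on that phenyl, so this comparison is only a loose guide. The expected result is a 1.4-fold lower number from compound 3 to compound 4 (0.15 log units; within the scatter) and thus no clear move beyond the scatter. For compound 4 the estimate is 300 nM with an expected range from 130 nM to 700 nM.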

Compound 4, half-maximal inhibitory concentration: 110 nM
Estimate against measurement, compound 4: 2.7-fold (0.44 log units) above; the whole stated range lies above it.
By their numbers in this assay, from the lowest: compounds 4, 1, 2 and 3 (each within the scatter of the next, the first and the last beyond it).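

In this assay, 2,4-difluorophenyl in place of phenyl on a saturated chain carbon bound to a nitrogen on an aromatic ring gives a 3.8-fold lower number from compound 3 to compound 4 (0.58 log units; beyond the scatter), so a change to the phenyl at this position can shift inhibition by more than the scatter. Going by these compounds alone, the only earlier step at this phenyl, hydrogen in place of trifluoromethyl, gave a 1.8-fold higher number from compound 2 to compound 3 (0.26 log units; within the scatter) and could not show this, which makes compound 4 the first clear sign that groups on this phenyl can strengthen inhibition. No measurement here explains why this change lowers the number.

On these data alone, compound 4 carries its fluorines together, so it remains open whether either fluorine alone would give the same step or whether both are needed. As far as these compounds go, it also remains open whether other groups on this phenyl, such as chlorine, methoxy or a nitrile, would lower the number as far, or whether an amine or a carboxylic acid there would keep any of the gain.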